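This account rests on a few compounds, and the source may have more. Where it says the series, first, only, none or still open, it means among the compounds named here.

Measured compounds:
Compound 1 `CS(=O)(=O)c1ccc(-c2cnc3[nH]cc(-c4nnc(-c5ccc(F)cc5)o4)c(=O)c3c2)cc1` gives 39.5% in a functional assay on HCT-116 cells (Homo sapiens) for positive allosteric modulation, read by MTT assay, with stated times of 24 h and 48 h, tested at 2.5 uM; on this read-out lower numbers stand for less inhibition of growth and higher numbers for more inhibition of growth at the one concentration tested.
Compound 2 `O=c1c(-c2nnc(-c3ccc(F)cc3)o2)c[nH]c2ncc(-c3cccnc3)cc12` gives 20.1% in this assay.
Compound 3 `O=c1c(-c2nnc(-c3ccc(F)cc3)o2)c[nH]c2ncc(-c3ccncc3)cc12` gives 19.6% in this assay.

Among these three numbers compound 1 stands highest. The steps of a number 19.4 percentage points lower from compound 1 to compound 2 (beyond the scatter) and a number 19.9 percentage points lower from compound 1 to compound 3 (beyond the scatter) both lie beyond the scatter, whereas the step of a number 0.5 percentage points lower from compound 2 to compound 3 (within the scatter) lies within it. All three measured steps concern the aromatic carbon that carries the 4-(methylsulfonyl)phenyl group of compound 1 and its pyridyl replacements.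

Compound 4 `Cc1cccc(-c2nnc(-c3c[nH]c4ncc(-c5ccc(S(C)(=O)=O)cc5)cc4c3=O)o2)c1` differs from compound 1 in another place: 3-methylphenyl in place of 4-fluorophenyl on an aromatic carbon. Among the compounds with values here, no measured pair touches this position, so the measured steps give no direct guidance on it. Since compound 1 retains its 4-(methylsulfonyl)phenyl group in compound 4, the account treats compound 1 and its value 39.5% as the anchor. The step of a number 1.5 percentage points lower from compound 1 to compound 4 (within the scatter) is therefore expected to stay within the scatter, in no clear direction. Compound 4 is estimated at 38%, with a range from 20% to 55%.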

Compound 4, percent growth inhibition at one concentration: 50.8%
Beside the measured number, compound 4's estimate is 12.8 percentage points below it, within the range that was stated.
By their numbers in this assay, from the lowest: compounds 3 and 2 (each within the scatter of the next); then compound 1; then compound 4.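

In this assay, within the data shown here, 3-methylphenyl in place of 4-fluorophenyl gives a number 11.3 percentage points higher from compound 1 to compound 4 (beyond the scatter), so the aryl group on this carbon of the five-membered aromatic ring does affect the read-out, which the earlier compounds, all carrying 4-fluorophenyl, could not show. The change also shows that the number can shift even though the two groups match in heavy atoms, hydrogen-bond donors, hydrogen-bond acceptors and net charge, so these counts do not separate them. Nothing available here explains why the number rises.

The compounds shown leave open whether the step follows from gaining the methyl group, losing the fluorine or moving the substituent, as plain phenyl, 4-methylphenyl and 3-fluorophenyl are not among them. Also open, as far as these compounds go, is how an aminophenyl or methoxyphenyl group would read here, and whether the step would hold with pyridin-3-yl in place of the 4-(methylsulfonyl)phenyl group.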